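The compounds below may be only part of what the source reports. "The series", "measured", "known", "first", "only" and "open" are said of these compounds alone.

Of the compounds shown here, three have numbers so far in an ADME assay on HepG2 cells (Homo sapiens) for cytotoxicity, read by CellTiter-Glo, with a stated time of 48 h (a higher number here means that more compound is tolerated, a lower number that less compound is tolerated), on this read-out. Compound 2 `CS(=O)(=O)c1ccc(-c2nc3ccc(Cl)cc3nc2-c2ccc(Cl)cc2)cc1` gives 2000 nM and lies within the scatter of compound 1 `C[S+]([O-])c1ccc(-c2nc3ccc(Cl)cc3nc2-c2ccc(Cl)cc2)cc1` at 1580 nM on these numbers, whereas compound 3 `CCCCNc1nc2ccccc2nc1S(C)(=O)=O` at 12600 nM stands clearly higher than both. Compound 4 `CS(=O)(=O)c1ccc(-c2nc3ccccc3nc2-c2ccc(Cl)cc2)cc1` has not yet been measured and departs from compound 2 through hydrogen in place of chloro on an aromatic carbon and nothing else. Within the data shown here, the only measured step, a 1.3-fold higher number from compound 1 to compound 2 (0.10 log units; within the scatter) and within the scatter, lies at the sulfur group and not at this chloro, so it bears on the change only indirectly. Compound 3 at 12600 nM differs from compound 2 in more than one place and cannot isolate the loss of chloro. Among the measured compounds shown here, no measured step speaks to this change directly, and no step beyond the scatter is expected for it in this assay here. The expected change is a 1.3-fold higher number from compound 2 to compound 4 (0.10 log units; within the scatter) and it is estimated to stay within the scatter. Compound 4 is estimated at 2500 nM with a range from 1100 nM to 6000 nM in this measurement.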

Compound 4, half-maximal cytotoxic concentration: 10000 nM
For compound 4 the middle estimate is 4.0-fold (0.60 log units) below the measured one; measured number above the stated range.
By their numbers in this assay, from the lowest: compounds 1 and 2 (each within the scatter of the next); then compounds 4 and 3 (each within the scatter of the next).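

In this assay, among these compounds, hydrogen in place of chloro on this aromatic carbon gives a 5.0-fold higher number from compound 2 to compound 4 (0.70 log units; beyond the scatter) and is the first single change here to lie beyond the scatter. Among the compounds shown here, the earlier step, a 1.3-fold higher number from compound 1 to compound 2 (0.10 log units; within the scatter) at the sulfur group, stayed within the scatter, so this position on the six-membered aromatic ring of carbon only is the one place so far where a single change moves the number clearly, though on one pair alone. Nothing measured here offers an explanation for this step. The compounds shown leave open how other groups at this position, such as a methoxy group, an amine or a carboxylic acid, would compare with chloro and hydrogen. They also leave open whether removing this chloro would give a similar step with the sulfur group of compound 1.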